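The source may hold more compounds than are shown below. What is called first, only, known or untested is meant among the compounds shown, and "the series" means these compounds.

Measured in a functional assay on RT-112 cells (Homo sapiens) for antiproliferative activity, read by MTT assay, with a stated time of 72 h; a higher number here means a weaker inhibitor of growth, a lower number a stronger inhibitor of growth:

compound 1 `COc1cc(Nc2ncnc3c(NC(=O)Nc4cccc(Oc5ccccc5)c4)cccc23)cc(OC)c1`: 14000 nM
compound 2 `COc1cc(Nc2ncnc3c(NC(=O)Nc4cc(Cl)c(Cl)cc4Cl)cccc23)cc(OC)c1`: 4890 nM
compound 3 `COc1cc(Nc2ncnc3c(NC(=O)Nc4cc(C(F)(F)F)cc(C(F)(F)F)c4)cccc23)cc(OC)c1`: 467 nM

Compound 2 (4890 nM) has the second highest of the three values. Compound 1 (14000 nM) lies higher and compound 3 (467 nM) lies lower, and both gaps are beyond the scatter.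

Compound 4 `COc1cc(Nc2ncnc3c(NC(=O)Nc4ccc([N+](=O)[O-])cc4)cccc23)cc(OC)c1` has not yet been measured. It differs from compound 2 by 4-nitrophenyl in place of 2,4,5-trichlorophenyl on an amide-type nitrogen.

For the measured compounds named here, no two measured compounds differ in one place only, so no single change serves as a precedent. The expectation rests only on the spread of the three values, and compound 2 (4890 nM) holds a middle position in that spread. No step beyond the scatter is expected in this assay, in either direction, and the estimated step reads a 1.2-fold lower number from compound 2 to compound 4 (0.09 log units; within the scatter). For compound 4 the expected value is 4000 nM, with an estimated range of 800 nM to 20000 nM.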

Compound 4, concentration for 50% growth inhibition: > 20000 nM
Compound 4 was reported as a limit (the forecaster's own chance of this, stated with the estimate: 10%); middle value at least 5.0-fold (0.69 log units) away from the limit.
By their numbers in this assay, from the lowest: compound 3; then compound 2; then compound 1. At a limit, above all of these: compound 4.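

In this assay compound 4 is reported only as a limit, > 20000 nM. Placing 4-nitrophenyl in place of 2,4,5-trichlorophenyl on the amide-type nitrogen, with the shared core unchanged, gives the first one-place comparison in the series, and the result is an at least 4.0-fold higher number from compound 2 to compound 4 (0.61 log units; beyond the scatter), so growth inhibition in this assay is sensitive to the aryl group at this position. This step marks a lower bound and not a measured size: the limit of > 20000 nM in this assay, at which 1 of the 4 values shown sits.

The pair cannot separate the departure of the three chlorine atoms from the arrival of the nitro group, as both change in the same step. Going by these compounds, whether a phenyl bearing an amine or a carboxylic acid on this nitrogen would fall nearer compound 2 or compound 4 remains open.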